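The source may report more compounds than this note shows. Statements on the series, on what has been measured and on what is new or still open speak of the compounds shown alone.

Compound 1 `FC(F)(F)c1ccc(-c2noc(-c3occc3Br)n2)cc1`, in a functional assay on DLD-1 cells (Homo sapiens) for inhibition, with a stated time of 48 h, at 37 degrees C; a higher number here means a weaker inhibitor of growth, a lower number a stronger inhibitor of growth: 130 nM
Compound 2 `FC(F)(F)c1ccc(-c2noc(-c3occc3Cl)n2)cc1`, in this assay: 350 nM
Compound 3 `Clc1ccc(-c2noc(-c3occc3Br)n2)nc1`, in this assay: 430 nM

Compound 1 and compound 2 share a core and differ by chloro in place of bromo on an aromatic carbon; this change gave a 2.7-fold higher number from compound 1 to compound 2 (0.43 log units; beyond the scatter). Compound 3 carries another core; the difference between the two cores is not broken down here. Compound 3 and compound 2 lie within the usual scatter of each other, and compound 3 sits furthest from compound 1 of the three.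

Compound 4 `Clc1ccc(-c2noc(-c3occc3Cl)n2)nc1` is not yet measured. It differs from compound 3 by chloro in place of bromo on an aromatic carbon, the same change as between compound 1 and compound 2, in the same place. The expected step is estimated, because of a 2.7-fold higher number from compound 1 to compound 2 (0.43 log units; beyond the scatter), at a 2.6-fold higher number from compound 3 to compound 4 (0.41 log units; beyond the scatter) in this assay. Compound 4 is therefore expected near 1100 nM, plausibly between 500 nM and 2500 nM.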

Compound 4, concentration for 50% growth inhibition: 600 nM
Compound 4: middle estimate off by 1.8-fold (0.26 log units), on the high side; measured number inside the range.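

Chloro in place of bromo on the furan gave, in this assay, a 1.4-fold higher number from compound 3 to compound 4 (0.14 log units; within the scatter). Placed beside the earlier step, the change shows no detectable dependence on the core: the same change on two cores in this assay, a 2.7-fold higher number (0.43 log units; beyond the scatter) from compound 1 to compound 2 and a 1.4-fold higher number (0.14 log units; within the scatter) from compound 3 to compound 4, 1.9-fold (0.29 log units) apart, within the scatter of two such steps. This rests on two pairs, so it does not establish that the step has the same size on both cores or that it would carry to any further core.

Still open, on these data alone, is how a group other than bromo or chloro on that furan carbon, such as methyl or a nitrile, would behave on either core. Also open, as far as these compounds go, is whether an amine or a carboxylic acid elsewhere on these compounds would alter the step.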